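Working notes on a series sitting at the assay limit

The source may report more compounds than this note shows. Statements on the series, on what has been measured and on what is new or still open speak of the compounds shown alone.

Compound 1 `CCc1ncn2c(S)nncc12`, compound 2 `Cc1ncn2c(S)nncc12` and compound 3 `Cc1nc(C(C)C)n2c(O)nncc12` have been measured; compound 4 `CCc1nc(C)c2cnnc(O)n12` has not. The read-out throughout is a functional assay for inhibition, with Homo sapiens as the target; on this read-out higher numbers stand for weaker inhibition and lower numbers for stronger inhibition.

In this assay compound 1 gives > 48000 nM, which is a limit of the assay and not a number. In this assay compound 2 gives > 48000 nM, again a limit. In this assay compound 3 gives > 48000 nM, also a limit. All three results thus sit on (the limit of > 48000 nM in this assay, at which 3 of the 3 values shown sit).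

Compound 2 differs from compound 1 by hydrogen in place of methyl on a saturated chain carbon bound to an aromatic carbon. The corresponding step, a step that the two limits leave unreadable from compound 1 to compound 2, has no readable size due to the limit of > 48000 nM in this assay, at which 3 of the 3 values shown sit.

Compound 4 differs from compound 3 by hydrogen in place of methyl on a saturated chain carbon bound to an aromatic carbon and a saturated chain carbon. This is the same kind of change as that between compound 1 and compound 2, not the same: in compound 3 the saturated chain carbon carrying the change is bound to an aromatic carbon and a saturated chain carbon, whereas in compound 1 it is bound to an aromatic carbon only. The difference between the cores of compound 1 and compound 3 is not broken down here.

In this assay the step that the limit leaves unreadable from compound 3 to compound 4 is expected. Among the compounds with values here, that expectation rests on compound 3 giving > 48000 nM and on (the limit of > 48000 nM in this assay, at which 3 of the 3 values shown sit), where the one measured step of this kind left no readable size. Compound 4 is expected to give 60000 nM in this assay, most probably as a limit again, with a range from 20000 nM to 200000 nM.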

Compound 4, half-maximal inhibitory concentration: > 48000 nM
Compound 4 ended at the assay's limit (the forecaster's own chance of this, stated with the estimate: 85%); the middle value does not contradict the limit.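

In this assay compound 4 gives > 48000 nM, which is a limit of the assay and not a number. No new step can be read from compound 3 to compound 4, because both results are limits: the limit of > 48000 nM in this assay, at which 4 of the 4 values shown sit.

The compounds shown leave open whether any change among them moves inhibition in this assay, as none of them gives a readable number.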